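A few compounds are considered here, and "the series" means these few. Any claim that something is new, unique, unknown or untested is made for them only; others in the source may bear on it.

Measured compounds and their values:

Compound 1, `O=C(Nc1ccnnc1)c1cc(C(F)(F)F)ccc1OCc1ccccc1`, in a physicochemical assay for lipophilicity, at pH 7.4 (on this read-out higher numbers stand for higher lipophilicity and lower numbers for lower lipophilicity), gives 5.4.
Compound 2, `CN1CCC(c2ccc(OCc3ccccc3)c(C(=O)Nc3ccnnc3)c2)CC1`, in this assay gives 2.3.
Compound 3, `C[C@@H]1CN(c2ccc(OCc3ccccc3)c(C(=O)Nc3ccnnc3)c2)C[C@H](C)O1`, in this assay gives 5.4.

Compound 3 stands level with compound 1, the two of them together the highest of the three numbers, as the step of no change at the digits printed from compound 1 to compound 3 (within the scatter) shows. Compound 2 lies far below them, with a number 3.10 log units higher from compound 2 to compound 3 (beyond the scatter) and a number 3.10 log units lower from compound 1 to compound 2 (beyond the scatter).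

Compound 4, `O=C(Nc1ccnnc1)c1cc(N2CCNCC2)ccc1OCc1ccccc1`, has not yet been measured in this assay. It differs from compound 3 in one place: piperazin-1-yl in place of 2,6-dimethylmorpholin-4-yl on an aromatic carbon. The measured step that bears on this change is a number 3.10 log units higher from compound 2 to compound 3 (beyond the scatter). In that step the 2,6-dimethylmorpholin-4-yl group that now leaves compound 3 is the group that entered, and its entry raised the value greatly. The step of no change at the digits printed from compound 1 to compound 3 (within the scatter) shows that this group sits level with trifluoromethyl. Removing it is therefore expected to bring the number down by a large step, a number 3.10 log units lower from compound 3 to compound 4 (beyond the scatter). For compound 4 a value of 2.3 is estimated, within 1.4 to 3.2.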

Compound 4, distribution coefficient: 1.9
Compound 4: the middle estimate sits 0.40 log units above what was measured; low and high end bracket the measured number.
By their numbers in this assay, from the lowest: compound 4; then compound 2; then compounds 1 and 3 (each within the scatter of the next).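

In this assay piperazin-1-yl, at the position para to the benzyloxy group, gives the lowest number of the four compounds, with a number 3.50 log units lower from compound 3 to compound 4 (beyond the scatter) and a number 3.50 log units lower from compound 1 to compound 4 (beyond the scatter) and also, against the 1-methylpiperidin-4-yl group, with a number 0.40 log units lower from compound 2 to compound 4 (beyond the scatter) at this same position. Piperazin-1-yl and 2,6-dimethylmorpholin-4-yl are each one six-membered non-aromatic ring with 2 hetero atoms, yet they stand at opposite ends of the series, so a ring of this size and hetero atom count does not by itself fix the number here. Nothing shown accounts for these differences. The compounds shown leave open where an unsubstituted morpholine ring would fall, and whether a methyl group on the free ring nitrogen of the piperazine would keep the number near that of compound 4.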